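The source may report more compounds than this note shows. Statements on the series, on what has been measured and on what is new or still open speak of the compounds shown alone.

In an assay on HEK293 cells for positive allosteric modulation of metabotropic glutamate receptor 2 (Rattus norvegicus), read by thallium flux, with a stated time of 2.5 min (a higher number here means that more compound is needed for the effect, a lower number that less compound is needed), compound 1 `Cc1c(OCCCCOc2ccc(C(=O)O)c(Cl)c2)ccc(C(=O)CC(C)C)c1O` gives 151 nM. Among the three compounds measured so far it holds the second highest number. Compound 3 `COc1cc(C(=O)O)ccc1OCCCCOc1ccc(C(=O)C(C)C)c(O)c1C` gives 113 nM, a value that lies within the scatter of compound 1, so the two cannot be told apart. For the measured compounds named here, compound 2 `Cc1c(OCCCCOc2ccc(C(=O)O)c(Cl)c2)ccc(C(=O)CC2CCCC2)c1O` gives 510 nM, and the only single-point step among the measured compounds, a 3.4-fold higher number from compound 1 to compound 2 (0.53 log units; beyond the scatter), is a modest one.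

Compound 4 `Cc1cc(OCCCCOc2ccc(C(=O)CC(C)C)c(O)c2C)ccc1C(=O)O` has not yet been measured. It differs from compound 1 in one place: methyl in place of chloro on an aromatic carbon. The exchange sits on an aromatic carbon of a six-membered aromatic ring of carbon only, ortho to a carboxy group and meta to a large group. Going by the values given here, no measured step touches this part of the molecule: the one known step concerns the saturated chain carbon bound to a carbonyl carbon at the other end. Compound 3 differs from compound 1 in more than one place, so only its value and that of compound 1 can be set side by side, and they fall within the scatter. With nothing pointing in either direction, no shift beyond the scatter is expected, and the expected step is a 1.1-fold higher number from compound 1 to compound 4 (0.03 log units; within the scatter). Compound 4 is therefore estimated at 160 nM, with a range from 60 nM to 450 nM.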

Compound 4, half-maximal effective concentration: 173 nM
Compound 4: the middle estimate sits 1.1-fold (0.03 log units) below what was measured; measured number inside the range.
By their numbers in this assay, from the lowest: compounds 3, 1 and 4 (each within the scatter of the next); then compound 2.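

For the compounds shown here, the exchange of chloro for methyl, on an aromatic carbon ortho to a carboxy group, gives the first single-place reading at this end of the molecule, and in this assay it produces a step (a 1.1-fold higher number from compound 1 to compound 4 (0.06 log units; within the scatter)) that stays within the scatter. The earlier step between compounds concerned only the saturated chain carbon bound to a carbonyl carbon, whereas this one shows that 4-carboxy-3-chlorophenyl and 4-carboxy-3-methylphenyl cannot be told apart here, even though one heavy atom, a chlorine, gives way to a carbon. Nothing at hand explains why the two groups give such similar numbers.

As far as these compounds go, a single exchange says little about the position as a whole, and it remains open whether an amine, a nitrile or a trifluoromethyl group on the same carbon would also leave the number within the scatter of compound 1. From the compounds shown here alone, it also remains open whether chloro and methyl would still match when the chain at the other end carries the cyclopentyl group of compound 2.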